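The source may report more compounds than this note shows. Statements on the series, on what has been measured and on what is new or still open speak of the compounds shown alone.

Compound 1 `O=C1NCCN1c1ccc(S(=O)(=O)Nc2ccc(F)cc2)cc1` gives the highest number among the three measured compounds in a functional assay on MCF7 cells (Homo sapiens) for antiproliferative activity, read by sulforhodamine B assay, with a stated time of 48 h (on this read-out lower numbers stand for stronger inhibition and higher numbers for weaker inhibition), namely 690 nM. Compound 2 `CCc1cccc(NS(=O)(=O)c2ccc(N3CCNC3=O)cc2)c1` gives 130 nM, and compound 3 `O=C1NCCN1c1ccc(S(=O)(=O)Nc2cccc(Br)c2)cc1` gives 100 nM. Compound 4 `CCCCOc1ccc(NS(=O)(=O)c2ccc(N3CCNC3=O)cc2)cc1` differs from compound 1 by a single exchange, (butoxy in place of fluoro on an aromatic carbon). The measured steps that bear on this both start from compound 1 and also alter the ring on the sulfonamide nitrogen: a 5.3-fold lower number from compound 1 to compound 2 (0.72 log units; beyond the scatter) and a 6.9-fold lower number from compound 1 to compound 3 (0.84 log units; beyond the scatter). Those steps exchanged the whole phenyl group rather than only the fluoro, so they guide only loosely. A modest lowering of the number is therefore expected for compound 4, about a 2.3-fold lower number from compound 1 to compound 4 (0.36 log units; beyond the scatter). Compound 4 is estimated at 300 nM, with a range from 100 nM to 900 nM.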

Compound 4, half-maximal inhibitory concentration: 870 nM
Compound 4: middle estimate off by 2.9-fold (0.46 log units), on the low side, and the stated range covers the measured number.
By their numbers in this assay, from the lowest: compounds 3 and 2 (each within the scatter of the next); then compounds 1 and 4 (each within the scatter of the next).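

Exchanging fluoro for butoxy on this aromatic carbon, para to a large group, gives a 1.3-fold higher number from compound 1 to compound 4 (0.10 log units; within the scatter). The earlier steps shown here replaced the whole phenyl group, whereas this one changes only the group on that ring, and a single fluorine and the 5 heavy atoms of butoxy cannot be told apart here. No measurement at hand explains this result. On these data alone, whether a methoxy, an amine or a carboxylic acid at this same place would also leave the number within the scatter remains open.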